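The source may report more compounds than this note shows. Statements on the series, on what has been measured and on what is new or still open speak of the compounds shown alone.

Compound 1 `CN1CCN(CCCS(=O)(=O)c2ccc3nc(NC(=O)NC(=O)c4cc(C5CC5)ccc4Cl)sc3c2)CC1` and compound 2 `CS(=O)(=O)c1ccc2sc(NC(=O)NC(=O)c3ccccc3Cl)nc2c1` share the same core, and both have been measured in a physicochemical assay for lipophilicity; on this read-out higher numbers stand for higher lipophilicity and lower numbers for lower lipophilicity. On that read-out compound 1 gives 2.9. Compound 2 gives 2.8, a value that sits within the usual scatter of the value of compound 1, so the two compounds stand level and neither can be called more or less lipophilic than the other. Among the compounds with values here, because they differ in more than one place, no single step connects them. Compound 3 `CN1CCN(CCCS(=O)(=O)c2ccc3nc(NC(=O)NC(=O)c4cc(-n5cccc5)ccc4Cl)sc3c2)CC1` has not yet been measured. It differs from compound 1 in one place: 1H-pyrrol-1-yl in place of cyclopropyl on an aromatic carbon. Within the data shown here, with no measured step to lean on, the expected change is small, likely no larger than the scatter, and is estimated as a number 0.20 log units higher from compound 1 to compound 3 (within the scatter). In this assay compound 3 is therefore expected to give about 3.1, with a range from 2.6 to 3.6.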

Compound 3, distribution coefficient: 2.6
For compound 3 the middle estimate is 0.50 log units above the measured one, within the range that was stated.
By their numbers in this assay, from the lowest: compounds 3, 2 and 1 (each within the scatter of the next).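

Within the data shown here, the first measured step at this position reads, in this assay, a number 0.30 log units lower from compound 1 to compound 3 (within the scatter), so 1H-pyrrol-1-yl in place of cyclopropyl leaves the two compounds level. This place, on an aromatic carbon para to a chloro group, therefore took a change from a three-membered non-aromatic ring of carbon only to a five-membered aromatic ring with 1 hetero atom, and the read-out did not move beyond the usual scatter. No separate measurement bears on why the two stand level.

Going by these compounds, whether an amine or a carboxylic acid at this same place would also stay level in this assay remains open. So does whether this swap would read the same with a different chain on the sulfonyl group of the shared core.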